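The source may report more compounds than this note shows. Statements on the series, on what has been measured and on what is new or still open speak of the compounds shown alone.

Compound 1 `CCc1c(O)c(=O)ccn1CCN(C)C`: 7.16
Compound 2 `CC(O)c1c(O)c(=O)ccn1CCN1CCCCC1`: 7.35

In a physicochemical assay for acid dissociation, read by spectrophotometry, compound 2 stands highest of the two numbers, with compound 1 nearest and within the scatter. Compound 3 `CCc1c(O)c(=O)ccn1CCN1CCCCC1` differs from compound 2 by hydrogen in place of hydroxy on a saturated chain carbon bound to an aromatic carbon and a saturated chain carbon. Going by the values given here, no step between two measured compounds is available to size this change. Compound 1, which also carries an ethyl, gives 7.16, so the step from compound 2 to compound 3 is expected to be a number 0.05 log units lower from compound 2 to compound 3 (within the scatter), small and not clearly beyond the scatter. Compound 3 is expected to give 7.3, with a range from 7 to 7.6.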

Compound 3, acid dissociation constant: 7.38
Estimate against measurement, compound 3: 0.08 log units below; the range from low to high includes it.
By their numbers in this assay, from the lowest: compounds 1, 2 and 3 (each within the scatter of the next).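

In this assay, going by these compounds alone, the change from 1-hydroxyethyl to ethyl gives a number 0.03 log units higher from compound 2 to compound 3 (within the scatter) and so leaves no readable mark on this number, which the single earlier pair could not show. Piperidin-1-yl in place of dimethylamino gives a number 0.22 log units higher from compound 1 to compound 3 (within the scatter) and likewise separates nothing beyond ordinary repeat variation. Nothing available explains why these numbers stay so close. Going by these compounds, whether an amine, a carboxylic acid or a longer chain on this saturated chain carbon would shift the number beyond the scatter remains open.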